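Dibromo to dichloro on the aryl ring of compound 3

This account rests on a few compounds, and the source may have more. Where it says the series, first, only, none or still open, it means among the compounds named here.

The series shares one core, first seen in compound 1 `CCCCN(CC)c1cc(C)nc2c1NC(=O)CN2c1ccc(C)cc1Cl`, for which the result in an assay on HEK-293T cells for displacement of a labelled ligand from corticotropin-releasing factor receptor 2 (Homo sapiens), read by scintillation counting, with a stated time of 2 h, tested at 1 uM (on this read-out higher numbers stand for more inhibition at the one concentration tested (going by the name of the read-out) and lower numbers for less inhibition), is "not determined" (no result reported). Compound 2 `CCCCN(CC)c1cc(C)nc2c1NC(=O)CN2c1ccc(C(C)C)cc1Br` gives 0.7% in this assay. Compound 3 `CCCCN(CC)c1cc(C)nc2c1NC(=O)CN2c1ccc(Br)cc1Br` gives 9.4%. Within the data shown here, the only single-point step among the measured compounds, a number 8.7 percentage points higher from compound 2 to compound 3 (within the scatter), changes bromo in place of isopropyl on an aromatic carbon. Among the measured compounds shown here, compound 3 thus stands as one of only two numbers in this assay, and its nearest neighbour, compound 2, lies within the scatter of it, so the two cannot be ranked.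

Compound 4 `CCCCN(CC)c1cc(C)nc2c1NC(=O)CN2c1ccc(Cl)cc1Cl` differs from compound 3 by 2,4-dichlorophenyl in place of 2,4-dibromophenyl on a nitrogen on an aromatic ring in a ring. For the measured compounds named here, no measured step exchanges one halogen for another at both aromatic carbons, so the step from compound 2 to compound 3, itself within the scatter, is the only guide, and it touched just one position. Going by the values given here, since both numbers recorded so far are low and the single step between them was small, a step of a number 2.4 percentage points lower from compound 3 to compound 4 (within the scatter) is expected, with no change beyond the scatter. Compound 4 is therefore estimated to give 7% in this assay, within a range from -6% to 20%.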

Compound 4, a percentage reported as inhibition, at one concentration (the size of the read-out at that concentration, not a potency): 0.9%
Compound 4: the middle estimate sits 6.1 percentage points above what was measured; measured number inside the range.
By their numbers in this assay, from the lowest: compounds 2, 4 and 3 (each within the scatter of the next).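

At the nitrogen on the aromatic ring, three ring bonds from the ring nitrogen, replacing 2,4-dibromophenyl with 2,4-dichlorophenyl gives a number 8.5 percentage points lower from compound 3 to compound 4 (within the scatter) in this assay. The earlier step changed the group on a single aromatic carbon, whereas this one exchanges the halogen on two aromatic carbons at once, and even this double exchange does not take the read-out outside the usual scatter, so bromine and chlorine cannot be told apart here and the three numbers now available form one unresolved group at the single concentration tested. No measurement is available that would explain this result, whether on the compounds themselves or on how they behave in the cells.

The compounds shown leave open whether any aryl group on this nitrogen can move the inhibition beyond the scatter, for instance a 2,4-dimethoxyphenyl or a 2,4-bis(trifluoromethyl)phenyl group, since every substituent seen so far is a halogen or a small alkyl group. They also leave open whether replacing the butyl and ethyl chains on the shared core with a longer chain or a carboxylic acid would change the read-out, as those chains stay the same throughout.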